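From cyclopropyl to acetyl on a shared core

The source may hold more compounds than are shown below. What is called first, only, known or untested is meant among the compounds shown, and "the series" means these compounds.

Compound 1 `Cc1ccc(CNc2nc(-c3ccccc3C(F)(F)F)nc3ccccc23)s1` gives 5100 nM in an assay on a protein complex for inhibition of ubiquitin carboxyl-terminal hydrolase 1/WD repeat-containing protein 48 (Homo sapiens), read by fluorescence; a lower number here means a stronger inhibitor, a higher number a weaker inhibitor. Compound 2 `Cc1cnc(-c2ccccc2C(C)C)nc1NCc1ccc(-c2ccnc(C(F)(F)F)c2)cc1` gives 320 nM in this assay, and compound 3 `Cc1cnc(-c2ccccc2C2CC2)nc1NCc1ccc(-c2cccnc2)cc1` gives 180 nM. Compound 3 has the lowest of the three numbers; its value and that of compound 2 lie within the usual scatter of each other, while the value of compound 1 stands well beyond it. Compound 4 `CC(=O)c1ccccc1-c1ncc(C)c(NCc2ccc(-c3cccnc3)cc2)n1` has not yet been measured. It differs from compound 3 in one place: acetyl in place of cyclopropyl on an aromatic carbon. Going by the values given here, no step between measured compounds covers this kind of change, so the expectation rests on the change alone: a modest shift toward a higher number is expected, as a 2.2-fold higher number from compound 3 to compound 4 (0.35 log units; beyond the scatter). For compound 4 the estimate in this assay is 400 nM, within a range from 120 nM to 1300 nM.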

Compound 4, half-maximal inhibitory concentration: 8700 nM
For compound 4 the middle estimate is 22-fold (1.34 log units) below the measured one; the measured number lies above the stated range.
By their numbers in this assay, from the lowest: compounds 3 and 2 (each within the scatter of the next); then compounds 1 and 4 (each within the scatter of the next).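

At this position, on an aromatic carbon ortho to a large group, the number in this assay responds strongly to the group present: acetyl in place of cyclopropyl gives a 48-fold higher number from compound 3 to compound 4 (1.68 log units; beyond the scatter). The two groups have the same heavy-atom count, so that count alone does not set the value here; acetyl differs in having no ring, a double bond and a hydrogen-bond acceptor.

The compounds shown leave open how a methoxy group, an amide or an ethyl chain would fare at this position. Nothing measured here explains the size of this step.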